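Dropping the Outer Ring from a Weakly Cytotoxic Sulfonamide

The source may report more compounds than this note shows. Statements on the series, on what has been measured and on what is new or still open speak of the compounds shown alone.

Measured compounds:
compound 1, `CC1CCN(C2CCN(S(=O)(=O)c3cccc(-c4ccccc4C(F)(F)F)c3)CC2)CC1`: > 5000 nM
compound 2, `CC1CCN(C2CCN(S(=O)(=O)c3cnc(Cl)s3)CC2)CC1`: > 10000 nM

Both results come from an ADME assay on HCT-116 cells (Homo sapiens) for cytotoxicity, read by CellTiter-Glo, with a stated time of 72 h; a lower number here means a stronger inhibitor, a higher number a weaker inhibitor. For compound 1 the assay reports only a limit, > 5000 nM, and no number. Compound 1 therefore sits at the limit of > 5000 nM in this assay, at which 1 of the 2 values shown sits. For compound 2 the assay likewise reports only a limit, > 10000 nM. Compound 2 sits at the limit of > 10000 nM in this assay, at which 1 of the 2 values shown sits. With two limits and no numbers, nothing can be said about an order between them; both simply fall outside the range where the assay reports a value.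

Compound 3, `CC1CCN(C2CCN(S(=O)(=O)c3cccc(C(F)(F)F)c3)CC2)CC1`, differs from compound 1 in one place: trifluoromethyl in place of 2-(trifluoromethyl)phenyl on an aromatic carbon. The six-membered aromatic ring of carbon only that leaves is not replaced by any ring. Within the data shown here, no measured step between compounds exists here to guide the size of this change, and the starting point of compound 1 is itself only a limit.

The step that the limit leaves unreadable from compound 1 to compound 3 is expected to be none beyond the scatter, with compound 3 most likely also reported as a limit. Compound 3 is estimated at 15000 nM, with a range from 4000 nM to 60000 nM.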

Compound 3, half-maximal inhibitory concentration: > 5000 nM
Compound 3 was reported as a limit (the forecaster's own chance of this, stated with the estimate: 85%); the middle value does not contradict the limit.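

No size of step can be read from compound 1 to compound 3, as the assay gives both compounds only as a limit and not as a number: the limit of > 5000 nM in this assay, at which 2 of the 3 values shown sit.

The compounds shown leave open whether trifluoromethyl in place of 2-(trifluoromethyl)phenyl changes cytotoxicity at all, and at what concentration, if any, either compound would begin to inhibit these cells.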